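Removing one methoxy from compound 2 in the cell assay

The source may hold more compounds than are shown below. What is called first, only, known or untested is meant among the compounds shown, and "the series" means these compounds.

Compound 1 `COc1cc([C@H](O)[C@H](CO)Oc2c(OC)cc(-c3cc(=O)c4c(O)cc(O)cc4o3)cc2OC)ccc1O` and compound 2 `COc1cc([C@H]2Oc3c(OC)cc(/C=C/COC(=O)c4ccc(O)cc4)cc3[C@@H]2COC(=O)c2ccc(O)cc2)cc(OC)c1O` are the two members of this series measured in a functional assay on RAW264.7 cells (Mus musculus) for inhibition, with a stated time of 24 h; a lower number here means a stronger inhibitor, a higher number a weaker inhibitor. In this assay compound 1 gives 29500 nM. In this assay, going by the values given here, compound 2 gives 223000 nM, the highest of the two numbers; the gap to compound 1 lies beyond the scatter, and no single-change step links the two structures, so the two values are noted side by side without further reading.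

Compound 3 `COc1cc([C@H]2Oc3c(OC)cc(/C=C/COC(=O)c4ccc(O)cc4)cc3[C@@H]2COC(=O)c2ccc(O)cc2)ccc1O` shares the core of compound 2 and differs from it in one place: hydrogen in place of methoxy on an aromatic carbon. The hydrogen replaces the methoxy on an aromatic carbon of a six-membered aromatic ring of carbon only, ortho to a hydroxy group and meta to a large group; cut one bond further out, 4-hydroxy-3,5-dimethoxyphenyl becomes 4-hydroxy-3-methoxyphenyl. Among the compounds with values here, no measured pair isolates this change, so the expected step is small, most likely within the scatter, with a slight lean toward a lower number; the estimated step is a 1.5-fold lower number from compound 2 to compound 3 (0.17 log units; within the scatter). Compound 3 is expected to give 150000 nM in this assay, within 50000 nM to 450000 nM.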

Compound 3, half-maximal inhibitory concentration: 23400 nM
For compound 3 the middle estimate is 6.4-fold (0.81 log units) above the measured one; the measured number lies below the stated range.
By their numbers in this assay, from the lowest: compounds 3 and 1 (each within the scatter of the next); then compound 2.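

In this assay, going by these compounds alone, replacing the methoxy with hydrogen, so that 4-hydroxy-3,5-dimethoxyphenyl becomes 4-hydroxy-3-methoxyphenyl, gives a 9.5-fold lower number from compound 2 to compound 3 (0.98 log units; beyond the scatter), the only single-change step so far. This aromatic carbon, ortho to a hydroxy group and meta to a large group, is therefore a place where one substituent change moves the number beyond the scatter, with hydrogen giving the stronger inhibitor of this pair, though this rests on a single pair and sets no trend. No supporting measurement bears on this step, and the shift stays unassigned.

The compounds shown carry only methoxy or hydrogen at this carbon, so it remains open whether a fluorine, an ethoxy or an amine there would sit with compound 2, with compound 3 or elsewhere. Also open, going by these compounds, is whether removing the remaining methoxy from the 4-hydroxy-3-methoxyphenyl group would extend the step, and whether the same change would give a similar step on the core of compound 1.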